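The source may report more compounds than this note shows. Statements on the series, on what has been measured and on what is new or still open speak of the compounds shown alone.

Measured compounds:
Compound 1 `CCCCCCCCCCCCCCCCCCNC(=O)NCc1c(OC)cc(OC)cc1OC`: in an assay on microsomes from intestinal mucosa for inhibition of acyl-CoA:cholesterol acyltransferase (Oryctolagus cuniculus) (a higher number here means a weaker inhibitor, a lower number a stronger inhibitor), compound 1 gives > 5000 nM, a limit of the assay.
Compound 2 `CCCCCCCC/C=C\CCCCCCCCNC(=O)Nc1ccccc1`: in this assay compound 2 gives > 5000 nM, a limit of the assay.
Compound 3 `CCCCCCCC/C=C\CCCCCCCCNC(=O)Nc1ccc(Oc2ccccc2)cc1`: in this assay compound 3 gives > 5000 nM, a limit of the assay.

Compound 2 stands only at a limit in this assay; no number is available for it, and the two other values shown are limits as well. Within the data shown here, the single measured step that touches compound 2 is a step that the two limits leave unreadable from compound 2 to compound 3, whose size the two limits leave unreadable. The common feature of the series is the limit of > 5000 nM in this assay, at which 3 of the 3 values shown sit.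

Compound 4 `CCCCCCCC/C=C\CCCCCCCCNC(=O)Nc1ccc(F)cc1F` has not yet been measured in this assay. The change from compound 2 is 2,4-difluorophenyl in place of phenyl on an amide-type nitrogen. Among the measured compounds shown here, no measured step bears on this change; the only step available is the unreadable one from compound 2 to compound 3, and every value shown sits at the limit. The expectation for compound 4 therefore rests on the limit of compound 2 alone, and the most probable outcome is another limit. The expected step is a step that the limit leaves unreadable from compound 2 to compound 4. For compound 4 the estimated value in this assay is 8000 nM, with a range from 2500 nM to 30000 nM.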

Compound 4, half-maximal inhibitory concentration: 4700 nM
Estimate against measurement, compound 4: 1.7-fold (0.23 log units) above; the range from low to high includes it.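

In this assay, among these compounds, compound 4 gives 4700 nM, the first value that is a number and not a limit of the assay. Replacing phenyl with 2,4-difluorophenyl on the amide-type nitrogen gives an at least 1.0-fold lower number from compound 2 to compound 4 (0.02 log units; that floor lies within the scatter), so the change can be read only as a floor, and that floor does not separate the two compounds. The steps between limits cannot be read, and the series as a whole still rests on its limit: the limit of > 5000 nM in this assay, at which 3 of the 4 values shown sit.

As far as these compounds go, the true size of this step remains open, as does whether one fluorine alone would give a numerical value in this assay. Also open, from the compounds shown here alone, is how a 2,4-dichlorophenyl or a 2,4-dimethoxyphenyl group would read at the same amide-type nitrogen.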